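The source may hold more compounds than are shown below. What is called first, only, known or untested is meant among the compounds shown, and "the series" means these compounds.

Measured compounds in an ADME assay on Vero cells (Chlorocebus sabaeus) for cytotoxicity, read by sulforhodamine B assay, with a stated time of 72 h; on this read-out lower numbers stand for stronger inhibition and higher numbers for weaker inhibition:
compound 1, `CN1Cc2ccc(OCCOc3ccccc3)cc2[C@@H](O)C1`
compound 2, `CN1CCc2cc(Oc3ccccc3)ccc2C1`
compound 3, `Oc1ccc2c(c1)C(O)CNC2`

In this assay compound 1 gives > 100000 nM, a limit of the assay and not a number. Compound 2 gives > 100000 nM, again a limit. Compound 3 gives > 100000 nM, also a limit. Compound 3 thus stands where every measured value of the series stands: the limit of > 100000 nM in this assay, at which 3 of the 3 values shown sit. Going by the values given here, no two measured compounds differ in only one place, so no step between measured compounds can be sized, and no pair of them shows an order.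

Compound 4, `CCN1Cc2ccc(O)cc2C(O)C1`, is not yet measured. It differs from compound 3 by ethyl in place of hydrogen on an amine nitrogen in a ring. With all three measured values sitting at the limit, no step size in this assay can be read from the series, and no step beyond the usual scatter is expected here. The estimate for compound 4 in this assay is 150000 nM, within 60000 nM to 400000 nM. The step this estimate means, a step that the limit leaves unreadable from compound 3 to compound 4, is expected to stay within the scatter, and this assay is expected most likely to report a limit once more.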

Compound 4, half-maximal inhibitory concentration: > 100000 nM
Compound 4 ended at the assay's limit (the forecaster's own chance of this, stated with the estimate: 85%); the middle value does not contradict the limit.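

No new step can be read from compound 3 to compound 4 in this assay: both values are limits of the assay. The compounds shown leave open whether any change to the shared core would give a measurable value in this read-out, since all remain at the limit: the limit of > 100000 nM in this assay, at which 4 of the 4 values shown sit.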